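This account rests on a few compounds, and the source may have more. Where it says the series, first, only, none or still open, it means among the compounds named here.

Compound 1 `COc1cccc(/C=N/NC(=S)Nc2ccccc2)c1O` gives 3000 nM.
Compound 2 `CCN(CC)c1ccc(/C=N/NC(N)=S)c(O)c1` gives 400 nM.
Compound 3 `Oc1ccccc1/C=N/NC(=S)Nc1ccccc1` gives 4000 nM.

In a functional assay on MCF7 cells (Homo sapiens) for antiproliferative activity, read by MTT assay, with a stated time of 72 h (a lower number here means a stronger inhibitor, a higher number a weaker inhibitor), compound 3 stands at the highest of the three numbers; compound 1 is nearest, within the scatter, and compound 2 is furthest, beyond it. Compound 4 `CCN(CC)c1ccc(/C=N/NC(=S)Nc2ccccc2)c(O)c1` differs from compound 3 by diethylamino in place of hydrogen on an aromatic carbon. Going by the values given here, the one measured step, a 1.3-fold higher number from compound 1 to compound 3 (0.12 log units; within the scatter), concerns a different group and lies within the scatter, so it says little about this change. Compound 2 carries the same diethylamino group but differs from compound 3 in a second place as well, and its value is the lower of the two. A lower number is therefore expected for compound 4, a step of a 5.7-fold lower number from compound 3 to compound 4 (0.76 log units; beyond the scatter). The estimate for compound 4 is 700 nM, with a range from 200 nM to 2500 nM.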

Compound 4, half-maximal inhibitory concentration: 1200 nM
Compound 4: the middle estimate sits 1.7-fold (0.23 log units) below what was measured, within the range that was stated.
By their numbers in this assay, from the lowest: compound 2; then compound 4; then compounds 1 and 3 (each within the scatter of the next).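

In this assay, the diethylamino group on the aromatic carbon para to a large group can now be read as a single change, on a core with phenyl on the amide-type nitrogen (a 3.3-fold lower number from compound 3 to compound 4 (0.52 log units; beyond the scatter)). The reverse reading also becomes available, as phenyl in place of hydrogen on that nitrogen, with diethylamino present, gives a step of its own (a 3.0-fold higher number from compound 2 to compound 4 (0.48 log units; beyond the scatter)). Nothing available explains either step. From the compounds shown here alone, it remains open whether a smaller amine such as dimethylamino, or a ring amine such as pyrrolidine, would give a similar step at this position. Going by these compounds, the effect of a small alkyl chain in place of phenyl on that nitrogen also remains open.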